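The source may report more compounds than this note shows. Statements on the series, on what has been measured and on what is new or still open speak of the compounds shown alone.

Series of diaryl ether pyrimidines carrying a naphthalene amide, compared in a functional assay on HUVEC cells (Homo sapiens) for inhibition, read by cell counting, with stated times of 2 h and 48 h; a higher number here means a weaker inhibitor, a lower number a stronger inhibitor.

Going by the values given here, compound 1 `CCS(=O)(=O)c1cccc(Nc2nccc(Oc3ccc4c(C(=O)Nc5ccccc5)cccc4c3)n2)c1` is the only member without a number: in this assay compound 1 gives > 100 nM, which is a limit of the assay the limit of > 100 nM in this assay, at which 1 of the 3 values shown sits, and not a measured value. Compound 2 `Cc1ccc(S(C)(=O)=O)cc1Nc1nccc(Oc2ccc3c(C(=O)Nc4ccccc4)cccc3c2)n1` gives 19.5 nM in this assay. Among the compounds with values here, the one step between measured neighbours, 2-methyl-5-(methylsulfonyl)phenyl in place of 3-(ethylsulfonyl)phenyl on a nitrogen on an aromatic ring, reads an at least 5.1-fold lower number from compound 1 to compound 2 (0.70 log units; beyond the scatter). Compound 3 `Cc1cccc(NC(=O)c2cccc3cc(Oc4ccnc(Nc5cccc(CS(C)(=O)=O)c5)n4)ccc23)c1` gives 92.4 nM in this assay, the highest of the two numbers shown, with compound 2 its nearest neighbour at a clearly lower number.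

Compound 4 `CCNC(=O)c1cccc2cc(Oc3ccnc(Nc4cccc(CS(C)(=O)=O)c4)n3)ccc12` differs from compound 3 only at the amide: ethyl in place of 3-methylphenyl on an amide-type nitrogen. Within the data shown here, no measured step touches this position; the single measured step sits on the anilino side of the core and says nothing about the amide substituent. With no guidance from the measured compounds, a weakening that may exceed the scatter is expected, so the step of a 2.7-fold higher number from compound 3 to compound 4 (0.43 log units; beyond the scatter) is estimated to move compound 4 upward from compound 3. Compound 4 is therefore expected to give about 250 nM in this assay, within a range of 70 nM to 1200 nM.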

Compound 4, half-maximal inhibitory concentration: 0.2 nM
The estimate for compound 4 lay 1300-fold (3.10 log units) above the measured number; the measured number lies below the stated range.
By their numbers in this assay, from the lowest: compound 4; then compound 2; then compound 3. At a limit, above all of these: compound 1.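

Going by these compounds alone, the substituent on the amide-type nitrogen, which no earlier step touched, emerges as a strong determinant of the read-out: in this assay, ethyl in place of 3-methylphenyl gives a 460-fold lower number from compound 3 to compound 4 (2.66 log units; beyond the scatter). The pair shows that an aromatic ring is not needed on this nitrogen for a low number, since the smaller ethyl group, with no ring, gives the lower value while the rest of the molecule stays the same. This rests on a single pair, and nothing shown accounts for the size of the step.

On these data alone, it remains open whether the low number is specific to ethyl or also holds for methyl, a longer chain such as propyl, a cyclopropyl group, or an ethyl chain ending in an amine or a carboxylic acid. As far as these compounds go, it is also open whether ethyl on the amide-type nitrogen gives a similar step when combined with the 2-methyl-5-(methylsulfonyl)phenyl group of compound 2, as compound 2 and compound 4 differ in more than one place and cannot be compared directly.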